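The source may hold more compounds than are shown below. What is called first, only, known or untested is meant among the compounds shown, and "the series" means these compounds.

In a functional assay on MCF7 cells (Homo sapiens) for cytotoxicity, read by MTT assay, with a stated time of 72 h (a lower number here means a stronger inhibitor, a higher number a weaker inhibitor), compound 1 (`O=C1c2c[n+]([O-])c3ccccc3c2C(=O)c2c1c1ccccc1n2CCCCn1ccnc1`) gives 130 nM and compound 2 (`O=C1c2c[n+]([O-])c3ccccc3c2C(=O)c2c1c1ccccc1n2CCN1CCCC1`) gives 320 nM on the same core, a modest difference (a 2.5-fold higher number from compound 1 to compound 2 (0.39 log units; beyond the scatter)). Compound 3 (`O=C1c2c[n+]([O-])c3ccccc3c2C(=O)c2c1c1ccccc1n2CCCCN1CCNCC1`) reaches 12000 nM and so has the highest number of the three, making it the weakest inhibitor in this small set. Compound 4 (`CCCN1CCN(CCCCn2c3c(c4ccccc42)C(=O)c2c[n+]([O-])c4ccccc4c2C3=O)CC1`) differs from compound 3 by a single change (propyl in place of hydrogen on an amine nitrogen in a ring): propyl in place of hydrogen on an amine nitrogen in a ring, which turns piperazin-1-yl into 4-propylpiperazin-1-yl.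

Within the data shown here, no measured step makes this change itself, so the evidence is indirect. The nearest guides are the two large steps that lead to the unsubstituted piperazin-1-yl group (a 92-fold higher number from compound 1 to compound 3 (1.97 log units; beyond the scatter) and a 38-fold higher number from compound 2 to compound 3 (1.57 log units; beyond the scatter)). They show that the group at the end of the chain can shift the number widely in this assay, and that compound 3 sits far from the other two. Compound 4 keeps the piperazine ring, so only part of that gap is expected to close. Among the measured compounds shown here, the expected change is a sizeable move to a lower number (an 8.0-fold lower number from compound 3 to compound 4 (0.90 log units; beyond the scatter)), though this rests on only three compounds. For compound 4 the estimated value is 1500 nM (expected range 300 nM to 7000 nM).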

Compound 4, half-maximal inhibitory concentration: 1280 nM
For compound 4 the middle estimate is 1.2-fold (0.07 log units) above the measured one; low and high end bracket the measured number.
By their numbers in this assay, from the lowest: compound 1; then compound 2; then compound 4; then compound 3.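

Within this assay, the step from compound 3 to compound 4 is the first direct reading of a substituent on the amine nitrogen in the ring: a 9.4-fold lower number from compound 3 to compound 4 (0.97 log units; beyond the scatter) shows that propyl in place of hydrogen there moves the number on its own, with the piperazine ring kept. It does not bring the group level with the other two end groups, since a 4.0-fold higher number from compound 2 to compound 4 (0.60 log units; beyond the scatter) against the pyrrolidin-1-yl compound and a 9.8-fold higher number from compound 1 to compound 4 (0.99 log units; beyond the scatter) against the 1H-imidazol-1-yl compound both leave compound 4 with the higher number. Nothing measured in this set accounts for these shifts.

With propyl the only substituent shown on that nitrogen, it remains open whether a methyl, a butyl or a longer chain would move the number further, less far or the other way. An acetyl or a 2-hydroxyethyl group at the same nitrogen is equally untested here, so no trend with substituent size or kind can be drawn from compound 3 and compound 4 alone.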